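Ethyl to propyl on the shared core: cytotoxicity notes

This account rests on a few compounds, and the source may have more. Where it says the series, first, only, none or still open, it means among the compounds named here.

Compound 1 `CCc1nnc(SCC(=O)c2ccc(Cl)cc2)n1N1C(=O)c2ccccc2C1=O` is the reference point of this small set. In a functional assay on HepG2 cells (Homo sapiens) for cytotoxicity, read by MTT assay, with a stated time of 48 h (a lower number here means a stronger inhibitor, a higher number a weaker inhibitor), compound 1 gives only a limit, > 200000 nM. Compound 2 `CCc1nnc(SCC(=O)c2ccc(C)cc2)n1N1C(=O)c2ccccc2C1=O` carries methyl in place of chloro on an aromatic carbon; in this assay compound 2 likewise gives only a limit, > 200000 nM. Compound 3 `CCOC(=O)CSc1nnc(CC)n1N1C(=O)c2ccccc2C1=O` has ethoxy in place of 4-chlorophenyl on a carbonyl carbon; in this assay compound 3 also reaches only a limit, > 200000 nM. The steps a step that the two limits leave unreadable from compound 1 to compound 2, a step that the two limits leave unreadable from compound 1 to compound 3 and a step that the two limits leave unreadable from compound 2 to compound 3 cannot be sized because of the limit of > 200000 nM in this assay, at which 3 of the 3 values shown sit.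

Compound 4 `CCCc1nnc(SCC(=O)c2ccc(Cl)cc2)n1N1C(=O)c2ccccc2C1=O` differs from compound 1 by methyl in place of hydrogen on a saturated chain carbon, two bonds along the chain from an aromatic carbon. For the measured compounds named here, none of the measured steps touches this chain, and none has a readable size, so no direction can be drawn from them. Compound 1 sits at the limit > 200000 nM in this assay. Compound 4 is therefore expected to sit at the same limit, with an estimate of 300000 nM (range 100000 nM to 1000000 nM). Going by the values given here, the step expected is a step that the limit leaves unreadable from compound 1 to compound 4, which means only that no change is expected to become readable.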

Compound 4, half-maximal inhibitory concentration: > 200000 nM
Compound 4 ended at the assay's limit (the forecaster's own chance of this, stated with the estimate: 85%); the middle value is on the limit's open side.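

No new step can be read between compound 1 and compound 4, because both values are limits of the assay: (the limit of > 200000 nM in this assay, at which 4 of the 4 values shown sit). The compounds shown leave open how far the ethyl to propyl change, or any other single change here, shifts cytotoxicity in this assay.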